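Replacing para-fluoro by methyl on the biaryl alcohol

The source may hold more compounds than are shown below. What is called first, only, known or untested is meant among the compounds shown, and "the series" means these compounds.

The shared core of compound 1, `CC(C)c1cc(C(C)(C)C)cc(-c2ccc(F)cc2)c1CO`, carries a 4-fluorophenyl group, and in a functional assay on RKE cells for antagonist activity at Vasoactive intestinal polypeptide receptor 1 (Rattus norvegicus), read by HTRF and cAMP accumulation, with stated times of 10 min and 30 min (a higher number here means a weaker inhibitor, a lower number a stronger inhibitor), compound 1 gives 740 nM. Among the two numbers available this is the higher one; the nearest is compound 3, `CC(C)c1cc(C(C)(C)C)cc(-c2cccc(N(C)C)c2)c1CO`, which in this assay gives 310 nM, a gap beyond the scatter. Compound 2, `CC(C)c1cc(C(C)(C)C)cc(-c2cccc(C(F)(F)F)c2)c1CO`, reaches only the limit of the assay in this assay, > 50000 nM, which is a limit and not a number (the limit of > 50000 nM in this assay, at which 1 of the 3 values shown sits).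

Compound 4, `Cc1ccc(-c2cc(C(C)(C)C)cc(C(C)C)c2CO)cc1`, differs from compound 1 by methyl in place of fluoro on an aromatic carbon. Going by the values given here, the only measured step, an at least 160-fold lower number from compound 2 to compound 3 (2.20 log units; beyond the scatter), concerns a different pair of groups at another aromatic carbon and does not bear directly on a fluoro-to-methyl exchange. Among the compounds with values here, no measured step therefore anchors this change, and a step within the scatter is expected, in no particular direction, as a 1.2-fold lower number from compound 1 to compound 4 (0.09 log units; within the scatter). In this assay compound 4 is expected to give about 600 nM, within a range from 250 nM to 1500 nM.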

Compound 4, half-maximal inhibitory concentration: 300 nM
Compound 4: the middle estimate sits 2.0-fold (0.30 log units) above what was measured; the measured number falls inside the stated range.
By their numbers in this assay, from the lowest: compounds 4 and 3 (each within the scatter of the next); then compound 1. At a limit, above all of these: compound 2.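

In this assay, methyl in place of fluoro gives a 2.5-fold lower number from compound 1 to compound 4 (0.39 log units; beyond the scatter), so this position, para to a large group, responds measurably to an exchange of one heavy atom for another. The earlier step concerned a different pair of groups at another aromatic carbon, whereas this one shows that a modest change in the number can occur here with no change in the counted hydrogen-bond donors, hydrogen-bond acceptors or net charge. Nothing measured here gives a cause for this step.

The compounds shown leave open whether an ethyl, a methoxy or an amine at this same position would lower the number further or raise it again. They also leave open whether methyl in place of fluoro gives a step of similar size when the ring carries dimethylamino.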